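A few compounds are considered here, and "the series" means these few. Any claim that something is new, unique, unknown or untested is made for them only; others in the source may bear on it.

Compound 3 `O=C(/C=C\Nc1ccc2[nH]ccc2c1)c1nc(-c2ccc(C(F)(F)F)cc2)n2ccccc12` gives 5190 nM in a functional assay on BT-474 cells (Homo sapiens) for cytotoxicity, read by MTT assay, with a stated time of 48 h (on this read-out lower numbers stand for stronger inhibition and higher numbers for weaker inhibition), the lowest of the two numbers shown, with compound 2 `COc1ccc(-c2nc(C(=O)/C=C\Nc3ccc(Cl)cc3)c3ccccn23)cc1` giving 37300 nM. Compound 1 `O=C(/C=C\Nc1ccc2cc[nH]c2c1)c1nc(-c2ccc(C(F)(F)F)cc2)n2ccccc12` gives only a limit of the assay, > 30000 nM. For the measured compounds named here, the one single-place step available, an at least 5.7-fold lower number from compound 1 to compound 3 (0.76 log units; beyond the scatter), shows that the ring on the amine nitrogen matters. Compound 4 `O=C(/C=C\Nc1ccc(Cl)cc1)c1nc(-c2ccc(C(F)(F)F)cc2)n2ccccc12` differs from compound 3 by 4-chlorophenyl in place of 1H-indol-5-yl on an amine nitrogen. Going by the values given here, no measured step covers exactly this change; compound 2 also carries a 4-chlorophenyl on that nitrogen but differs elsewhere too, and its number sits well above that of compound 3. A weakening is therefore expected, estimated as a 3.9-fold higher number from compound 3 to compound 4 (0.59 log units; beyond the scatter). Compound 4 is expected to give about 20000 nM, between 5000 nM and 60000 nM.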

Compound 4, half-maximal inhibitory concentration: 3820 nM
The estimate for compound 4 lay 5.2-fold (0.72 log units) above the measured number, outside the stated range (below it).
By their numbers in this assay, from the lowest: compounds 4 and 3 (each within the scatter of the next); then compound 2.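

Swapping the two rings on the amine nitrogen gives a 1.4-fold lower number from compound 3 to compound 4 (0.13 log units; within the scatter), so 4-chlorophenyl, with no hydrogen-bond donor, serves as well here as 1H-indol-5-yl, which has one. With 4-chlorophenyl held fixed, trifluoromethyl in place of methoxy on an aromatic carbon gives a 9.8-fold lower number from compound 2 to compound 4 (0.99 log units; beyond the scatter), the first single-place view of that change. The comparison with the 1H-indol-6-yl compound gives an at least 7.8-fold lower number from compound 1 to compound 4 (0.89 log units; beyond the scatter), but it rests on a limit: the limit of > 30000 nM in this assay, at which 1 of the 4 values shown sits.

As far as these compounds go, whether the trifluoromethyl gain also holds with 1H-indol-5-yl on the nitrogen remains open. So does the effect of an unsubstituted phenyl on that nitrogen, or of a carboxylic acid in place of trifluoromethyl.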